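A few compounds are considered here, and "the series" means these few. Any claim that something is new, unique, unknown or untested is made for them only; others in the source may bear on it.

In an ADME assay on the whole organism (Portal vein, Rattus norvegicus, strain Sprague-Dawley), at a dose of 10 mg/kg by the oral route (on this read-out lower numbers stand for lower exposure and higher numbers for higher exposure at the dose given), compound 1 `CCCCNc1nc(N)nc2ccccc12` gives 1520 ng.h/mL while compound 2 `CCCCNc1nc(N)nc2cccc(C(=O)N(C)Cc3ccccc3)c12` gives 621 ng.h/mL and so stands lowest of the two, with a gap beyond the scatter. The change (1-phenylethyl)amino in place of benzyl(methyl)amino on a carbonyl carbon puts (1-phenylethyl)amino on the carbonyl carbon in place of benzyl(methyl)amino, and gives compound 3 `CCCCNc1nc(N)nc2cccc(C(=O)N[C@@H](C)c3ccccc3)c12` the same atoms as compound 2, joined differently. For the measured compounds named here, no measured pair shows such a change. The step expected in this assay is a 1.2-fold lower number from compound 2 to compound 3 (0.09 log units; within the scatter) and thus none beyond the scatter. Compound 3 is expected at 500 ng.h/mL with an estimated range from 170 ng.h/mL to 1500 ng.h/mL on this reading.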

Compound 3, area under the concentration-time curve: 902 ng.h/mL
Compound 3: middle estimate off by 1.8-fold (0.26 log units), on the low side; the range from low to high includes it.
By their numbers in this assay, from the lowest: compounds 2, 3 and 1 (each within the scatter of the next, the first and the last beyond it).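

In this assay, placing (1-phenylethyl)amino on the carbonyl carbon in place of benzyl(methyl)amino gives a 1.5-fold higher number from compound 2 to compound 3 (0.16 log units; within the scatter). At this position, then, a rearrangement of the same atoms that brings in a hydrogen-bond donor and a defined stereocentre leaves the two compounds indistinguishable on this read-out. No available evidence bears on this result. Still open, from the compounds shown here alone, is how the other mirror-image form of (1-phenylethyl)amino would compare. Also open, going by these compounds, is whether a different kind of group on the carbonyl carbon, such as morpholine, would separate from compound 2 beyond the scatter.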